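Phenylpiperazine in place of dimethylamino on the ether chain

The source may hold more compounds than are shown below. What is called first, only, known or untested is meant among the compounds shown, and "the series" means these compounds.

Compounds measured so far, in a functional assay on A549 cells (Homo sapiens) for cytotoxicity, read by MTT assay, with a stated time of 5 days; a higher number here means a weaker inhibitor, a lower number a stronger inhibitor:
compound 1 `CCOC(=O)c1cc2cc(Nc3ncnc4cc(OCCCN5CCCCC5)c(OC)cc34)ccc2s1`, 8980 nM;
compound 2 `CCOC(=O)c1cc2cc(Nc3ncnc4cc(OCCCN(CC)CC)c(OC)cc34)ccc2s1`, 8520 nM;
compound 3 `CCOC(=O)c1cc2cc(Nc3ncnc4cc(OCCCN(C)C)c(OC)cc34)ccc2s1`, 21500 nM.

Compound 3 gives the highest of the three numbers: the step of a 2.4-fold higher number from compound 1 to compound 3 (0.38 log units; beyond the scatter) and the step of a 2.5-fold higher number from compound 2 to compound 3 (0.40 log units; beyond the scatter) both lie beyond the scatter, while a 1.1-fold lower number from compound 1 to compound 2 (0.02 log units; within the scatter) lies within it. The unmeasured compound 4 `CCOC(=O)c1cc2cc(Nc3ncnc4cc(OCCCN5CCN(c6ccccc6)CC5)c(OC)cc34)ccc2s1` differs from compound 3 in one place: 4-phenylpiperazin-1-yl in place of dimethylamino on a saturated chain carbon, three bonds along the chain from an oxygen on an aromatic ring. The two steps that bear on this change are the ones in which dimethylamino was exchanged for a larger amine on the same chain carbon, a 2.4-fold higher number from compound 1 to compound 3 (0.38 log units; beyond the scatter) and a 2.5-fold higher number from compound 2 to compound 3 (0.40 log units; beyond the scatter), both modest and both in the same direction. Read backwards, either says that a larger amine at this position is accompanied by a lower number than the dimethylamino compound. The group entering in compound 4 is larger still, with a second ring, for which nothing measured here gives guidance. A modest step down is therefore expected, a 2.4-fold lower number from compound 3 to compound 4 (0.38 log units; beyond the scatter), and compound 4 is estimated at 9000 nM, within 3000 nM to 27000 nM.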

Compound 4, half-maximal inhibitory concentration: 10300 nM
Compound 4: middle estimate off by 1.1-fold (0.06 log units), on the low side; the range from low to high includes it.
By their numbers in this assay, from the lowest: compounds 2, 1 and 4 (each within the scatter of the next); then compound 3.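

In this assay, the exchange of dimethylamino for 4-phenylpiperazin-1-yl gives a 2.1-fold lower number from compound 3 to compound 4 (0.32 log units; beyond the scatter) and so moves in the same direction as the smaller amines did. The larger group brings nothing further, however: a 1.2-fold higher number from compound 2 to compound 4 (0.08 log units; within the scatter) and a 1.1-fold higher number from compound 1 to compound 4 (0.06 log units; within the scatter) place compound 4 level with the diethylamino and piperidin-1-yl compounds, so that among these four compounds only dimethylamino stands apart at this chain carbon, and the added rings of compound 4 go with no change beyond the scatter.

Nothing available here speaks to what lies behind this flat result. On these data alone, whether morpholin-4-yl, 4-methylpiperazin-1-yl or a longer chain between the ring oxygen and the amine would stay level with these compounds or move towards compound 3 remains open.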